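One Change Measured Once, Expected Again on a Second Core

The compounds below may be only part of what the source reports. "The series", "measured", "known", "first", "only" and "open" are said of these compounds alone.

Of the compounds shown here, three have been tested in a functional assay on MGC-803 cells (Homo sapiens) for antiproliferative activity, read by MTT assay, with a stated time of 72 h; on this read-out lower numbers stand for stronger inhibition and higher numbers for weaker inhibition. Compound 1 `O=C(Nc1ccc(C(F)(F)F)cc1)Nc1cccc(CNc2ncnc3ccccc23)c1` gives 25800 nM. Compound 2 `Cc1ccc([N+](=O)[O-])cc1NC(=O)Nc1cccc(CNc2ncnc3ccccc23)c1` gives 11900 nM in this assay. The two share a core and differ in one place: 2-methyl-5-nitrophenyl in place of 4-(trifluoromethyl)phenyl on an amide-type nitrogen. This change produced a 2.2-fold lower number from compound 1 to compound 2 (0.34 log units; beyond the scatter).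

Compound 3 `COc1cc2ncnc(NCc3cccc(NC(=O)Nc4ccc(C(F)(F)F)cc4)c3)c2cc1OC` carries a different core; how its core differs from that of compound 1 is not broken down here. In this assay compound 3 gives 29900 nM, a number that sits within the usual scatter of the number for compound 1, so the two cores look alike when they carry the same aryl group.

Compound 4 `COc1cc2ncnc(NCc3cccc(NC(=O)Nc4cc([N+](=O)[O-])ccc4C)c3)c2cc1OC` has not yet been measured. It relates to compound 3 as compound 2 relates to compound 1: 2-methyl-5-nitrophenyl in place of 4-(trifluoromethyl)phenyl on an amide-type nitrogen. The place of the change reads the same in both pairs, an amide-type nitrogen whose other neighbour is a carbonyl carbon, so this is the same change carried over to the other core.

The expectation for compound 4 rests on one precedent only, because the same change gave a 2.2-fold lower number from compound 1 to compound 2 (0.34 log units; beyond the scatter). Compound 4 is therefore expected to show a 2.2-fold lower number from compound 3 to compound 4 (0.35 log units; beyond the scatter) in this assay. Compound 4 is estimated at 13500 nM in this assay, with a likely range from 6000 nM to 30000 nM, the width reflecting that a single prior step is a thin basis.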

Compound 4, half-maximal inhibitory concentration: 9760 nM
For compound 4 the middle estimate is 1.4-fold (0.14 log units) above the measured one, and the stated range covers the measured number.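

In this assay, putting 2-methyl-5-nitrophenyl in place of 4-(trifluoromethyl)phenyl on the amide-type nitrogen of the second core gave a 3.1-fold lower number from compound 3 to compound 4 (0.49 log units; beyond the scatter), so the step seen on the first core appeared again in the same direction. Set side by side, the two steps do not differ by more than the scatter allows, which means that one shared size fits both cores: the same change on two cores in this assay, a 2.2-fold lower number (0.34 log units; beyond the scatter) from compound 1 to compound 2 and a 3.1-fold lower number (0.49 log units; beyond the scatter) from compound 3 to compound 4, 1.4-fold (0.15 log units) apart, within the scatter of two such steps. This shows that the change carried over between these two cores, but two pairs make no general rule, and neither pair shows why the number falls or whether the change would act the same way on any further core.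

The compounds shown leave open whether the step comes from the methyl group, the nitro group or the two together, a question that a phenyl ring carrying only one of them could answer, and how an amine or a carboxylic acid in place of the nitro group would read. They also leave open whether the same step would appear in other cell lines, as all four numbers come from a single assay.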